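A few compounds are considered here, and "the series" means these few. Any claim that something is new, unique, unknown or untested is made for them only; others in the source may bear on it.

Measured in a functional assay on THP-1 cells (Homo sapiens) for inhibition, read by sulforhodamine B assay, with a stated time of 48 h, tested at 50 uM; on this read-out lower numbers stand for less inhibition of growth and higher numbers for more inhibition of growth at the one concentration tested:
- compound 1 `COc1cc(/C=C/C(=O)/C=C/c2ccco2)ccc1OCc1cn(CCCOc2cc(=O)oc3ccccc23)nn1`: 57%
- compound 2 `COc1ccccc1/C=C/C(=O)/C=C/c1ccc(OCc2cn(CCCOc3cc(=O)oc4ccccc34)nn2)c(OC)c1`: 50%
- compound 3 `COc1ccc(/C=C/C(=O)/C=C/c2ccc(OCc3cn(CCCOc4cc(=O)oc5ccccc45)nn3)c(OC)c2)cc1`: 56%

Not yet measured: compound 4 `COc1cc(/C=C/C(=O)/C=C/c2ccccc2)ccc1OCc1cn(CCCOc2cc(=O)oc3ccccc23)nn1`.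

In this assay, compound 3 gives 56%, which lies within the scatter of both other compounds, so the three values show no order. Going on to compound 4 is hydrogen in place of methoxy on an aromatic carbon, turning the 4-methoxyphenyl into phenyl.

Going by the values given here, no measured step makes this exact change. The nearest ones alter the same end of the molecule: a number 1 percentage points lower from compound 1 to compound 3 (within the scatter), a number 7 percentage points lower from compound 1 to compound 2 (within the scatter) and a number 6 percentage points higher from compound 2 to compound 3 (within the scatter). The last of these exchanges 2-methoxyphenyl for 4-methoxyphenyl. Among the compounds with values here, all three stay within the scatter, so these changes at this end have so far left this assay flat, although no measured compound carries a plain phenyl there. The expected move is a number 2 percentage points lower from compound 3 to compound 4 (within the scatter), meaning no shift beyond the scatter is expected. For compound 4 the estimated value is 54%, with an expected range of 43% to 65%.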

Compound 4, percent growth inhibition at one concentration: 48%
The estimate for compound 4 lay 6 percentage points above the measured number, within the range that was stated.
By their numbers in this assay, from the lowest: compounds 4, 2, 3 and 1 (each within the scatter of the next).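

Hydrogen in place of methoxy gives a number 8 percentage points lower from compound 3 to compound 4 (within the scatter) in this assay and a number 2 percentage points lower from compound 2 to compound 4 (within the scatter) on the same read-out, so the plain phenyl at this end stays within the scatter of both methoxy-bearing rings. Phenyl in place of furan-2-yl gives a number 9 percentage points lower from compound 1 to compound 4 (within the scatter) and likewise stays within the scatter, so none of the four end groups in compounds 1 to 4 separates from the others. Nothing available explains this flat result.

Open, from the compounds shown here alone, is whether a dimethylamino group or a carboxylic acid on this phenyl would give a step beyond the scatter in this assay. Also open, going by these compounds, is whether a longer chain in place of the ethenyl link would do so.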